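A few compounds are considered here, and "the series" means these few. Any claim that something is new, unique, unknown or untested is made for them only; others in the source may bear on it.

Measured so far in a functional assay on DU-145 cells (Homo sapiens) for inhibition, read by trypan blue exclusion, with a stated time of 96 h; on this read-out lower numbers stand for stronger inhibition of growth and higher numbers for weaker inhibition of growth:

compound 1, `COc1ccc(/C=C(/Sc2ccc(Br)cc2)C(=O)c2ccc(Br)cc2)cc1`, gives 25000 nM
compound 2, `O=C(/C(=C\c1ccc(O)cc1O)Sc1ccc(Br)cc1)c1ccc(Cl)cc1`, gives 50000 nM
compound 3, `COc1ccc(/C=C(/SCc2ccc(Cl)cc2)C(=O)c2ccc(Cl)cc2)cc1`, gives 10000 nM

Among these three, compound 3 stands at the lowest number, which on this read-out means the strongest inhibition of growth of the three. Its nearest neighbour is compound 1, whose number is higher by a margin beyond the usual scatter, and compound 2 lies further away still. All three share the same core, an enone carrying a sulfur substituent, and differ in the groups hung on it.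

Compound 4, `COc1ccc(/C=C(/Sc2ccc(Br)cc2)C(=O)c2ccc(Cl)cc2)cc1`, is the next compound to be measured in this assay. It is compound 3 with one change: 4-bromophenyl in place of 4-chlorobenzyl on a sulfur. Within the data shown here, no measured pair shows exactly this exchange on its own, so its effect can only be guessed from the neighbours. Compound 1 also carries a 4-bromophenyl on the sulfur and gives a higher number than compound 3, although it differs from compound 4 elsewhere as well.

On that basis, a modest move toward weaker inhibition is expected, roughly at the edge of the scatter, written as a 2.0-fold higher number from compound 3 to compound 4 (0.30 log units; within the scatter). Compound 4 is therefore estimated at 20000 nM, with a likely range from 8000 nM to 50000 nM.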

Compound 4, concentration for 50% growth inhibition: 50000 nM
The estimate for compound 4 lay 2.5-fold (0.40 log units) below the measured number; measured number inside the range.
By their numbers in this assay, from the lowest: compound 3; then compounds 1, 2 and 4 (each within the scatter of the next).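

In this assay, among these compounds, the exchange of 4-chlorobenzyl for 4-bromophenyl on the sulfur gives a 5.0-fold higher number from compound 3 to compound 4 (0.70 log units; beyond the scatter), the first direct reading at this position, and it shows that this single change is large enough to stand clear of the usual scatter. The other two single changes do not: 4-methoxyphenyl in place of 2,4-dihydroxyphenyl on the double-bonded chain carbon gives no change at the digits printed from compound 2 to compound 4 (within the scatter), and chloro in place of bromo on an aromatic carbon gives a 2.0-fold higher number from compound 1 to compound 4 (0.30 log units; within the scatter), so among these four compounds only the change on the sulfur separates two numbers beyond the scatter. Nothing measured alongside these numbers accounts for the step at the sulfur.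

As far as these compounds go, the change on the sulfur swaps benzyl for phenyl and chlorine for bromine together, so it remains open which of the two carries the step, and a 4-chlorophenyl or a 4-bromobenzyl group on the sulfur would pull them apart. From the compounds shown here alone, how a longer chain such as 2-phenylethyl, or an amine, would read on the sulfur also remains open.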